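The source may hold more compounds than are shown below. What is called first, only, known or untested is meant among the compounds shown, and "the series" means these compounds.

Measured in a functional assay on PANC-1 cells (Homo sapiens) for cytotoxicity, read by WST assay, with a stated time of 24 h; on this read-out lower numbers stand for stronger inhibition and higher numbers for weaker inhibition:
- Compound 1 `O=C(/C=C\CCCCCCc1ccccc1)N1CCCCC1`: > 100000 nM
- Compound 2 `O=C(CCCCCCc1ccccc1)N1CCCCC1`: > 100000 nM
- Compound 3 `Cc1ccc(CCCCCCCCC(=O)N2CCCCC2)cc1`: > 100000 nM

None of these entries is an exact number. Each one is a limit of the assay, and the overall picture is the limit of > 100000 nM in this assay, at which 3 of the 3 values shown sit. Compound 3 therefore has no exact place on the scale, and its entry of > 100000 nM is a limit.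

The next compound to be tested is compound 4 `O=C(CCCCCCCCc1cccc(F)c1)N1CCCCC1`. It carries 3-fluorophenyl in place of 4-methylphenyl on a saturated chain carbon, eight bonds along the chain from a carbonyl carbon.

Within the data shown here, no two measured compounds differ in one place only, so the data give no direct measure of what such a swap can do. Compounds 1, 2 and 3 all share the same limit, and nothing in them points to a direction for the change. The expectation is therefore for no step beyond the usual scatter, and another limit is the most likely report from this assay. The estimated change is a step that the limit leaves unreadable from compound 3 to compound 4. For compound 4 the expected value is 130000 nM, with an estimated range from 60000 nM to 300000 nM.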

Compound 4, half-maximal inhibitory concentration: > 100000 nM
Compound 4: a limit, no number (the forecaster's own chance of this, stated with the estimate: 80%); the middle value lies beyond the limit too.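

In this assay, no step can be read from compound 3 to compound 4, because both entries are limits and not exact numbers: the limit of > 100000 nM in this assay, at which 4 of the 4 values shown sit.

The compounds shown leave open whether 3-fluorophenyl in place of 4-methylphenyl changes the effect on these cells at all, and which structure, if any, would give an exact number.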